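A Second Chloro on the Aryl Sulfone

The compounds below may be only part of what the source reports. "The series", "measured", "known", "first", "only" and "open" are said of these compounds alone.

Compound 1 `CC1CCN(c2c(S(=O)(=O)c3cccc(Cl)c3)cnc3cc(Cl)ccc23)CC1` was tested in an assay on isolated protein for displacement of a labelled ligand from metabotropic glutamate receptor 5 (Homo sapiens), with a stated time of 60 min, tested at 1 uM (a lower number here means less inhibition, a higher number more inhibition at the concentration tested (going by the name of the read-out)), and gave 92%. Compound 2 `Cc1ccc2ncc(S(=O)(=O)c3ccc(Cl)c(Cl)c3)c(N3CCC(C)CC3)c2c1` gave 82% in this assay, a number that lies within the usual scatter of the value of compound 1, so the two cannot be told apart. Compound 3 `CC1CCN(c2c(S(=O)(=O)c3ccc(Cl)c(Cl)c3)cnc3cc(Cl)ccc23)CC1` differs from compound 1 in one place: chloro in place of hydrogen on an aromatic carbon. Within the data shown here, no measured pair shows this step on its own, and compound 2 already carries the 3,4-dichlorophenyl. The step of a number 4 percentage points lower from compound 1 to compound 3 (within the scatter) is therefore expected to stay within the scatter. Compound 3 is estimated at 88%, between 76% and 96%.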

Compound 3, a percentage reported as inhibition, at one concentration (the size of the read-out at that concentration, not a potency): 89%
For compound 3 the middle estimate is 1 percentage points below the measured one; low and high end bracket the measured number.
By their numbers in this assay, from the lowest: compounds 2, 3 and 1 (each within the scatter of the next).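

Turning the 3-chlorophenyl into the 3,4-dichlorophenyl gives a number 3 percentage points lower from compound 1 to compound 3 (within the scatter) in this assay at the one concentration tested. Among these compounds, this is the first step that isolates a change on the aryl sulfone, and it shows that a chloro on this aromatic carbon, ortho to a chloro group and para to a large group, leaves the inhibition within the scatter. No available evidence gives a reason for this result. Going by these compounds, whether a methoxy group or an amine on this carbon would keep the inhibition stays open. Potency also stays open, since a single-concentration reading does not give it.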